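Shifting the Hydroxyl: From Compound 1 to Compound 4

The compounds below may be only part of what the source reports. "The series", "measured", "known", "first", "only" and "open" are said of these compounds alone.

Compound 1, `COc1ccc(C(c2ccccc2O)c2cccc3ccccc23)c(OC)c1OC`: 13600 nM
Compound 2, `C=CCC(O)(c1ccc(OC)c(OC)c1OC)c1cccc2ccccc12`: 10700 nM
Compound 3, `C=C(c1ccc(OC)c(OC)c1OC)c1cccc2ccccc12`: 19800 nM

All three values come from a functional assay on A549 cells (Homo sapiens) for inhibition, read by sulforhodamine B assay, with a stated time of 48 h; a higher number here means a weaker inhibitor, a lower number a stronger inhibitor. Compound 1 stands second highest of the three numbers; its nearest neighbour is compound 2 and its furthest is compound 3, and both gaps lie within the scatter of repeated measurements, so no order among the three can be claimed. Compound 4, `COc1ccc(C(c2ccc(O)cc2)c2cccc3ccccc23)c(OC)c1OC`, has not yet been measured in this assay. It differs from compound 1 in one place: 4-hydroxyphenyl in place of 2-hydroxyphenyl on a saturated chain carbon bound to two aromatic carbons. Going by the values given here, no pair of measured compounds differs in a single place, so there is no measured step to lean on. Since the same atoms are merely joined differently, the step of a 1.1-fold lower number from compound 1 to compound 4 (0.04 log units; within the scatter) is expected to remain within the usual scatter, in no particular direction. Compound 4 is therefore estimated at 12500 nM in this assay, with a range from 5000 nM to 30000 nM.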

Compound 4, half-maximal inhibitory concentration: 16400 nM
Beside the measured number, compound 4's estimate is 1.3-fold (0.12 log units) below it, and the stated range covers the measured number.
By their numbers in this assay, from the lowest: compounds 2, 1, 4 and 3 (each within the scatter of the next).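

Going by these compounds alone, compound 4 gives the first comparison that differs in one place. In this assay, 4-hydroxyphenyl in place of 2-hydroxyphenyl on a saturated chain carbon bound to two aromatic carbons gives a 1.2-fold higher number from compound 1 to compound 4 (0.08 log units; within the scatter), so the two arrangements of the hydroxyl cannot be told apart on this core. Nothing available bears on why this is so.

The compounds shown leave open whether the hydroxyl itself matters at this place. An unsubstituted phenyl, or a methoxy or an amine in place of the hydroxyl, could settle that.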